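A few compounds are considered here, and "the series" means these few. Any claim that something is new, unique, unknown or untested is made for them only; others in the source may bear on it.

Three compounds share one core and were tested in a functional assay on PANC-1 cells (Homo sapiens) for inhibition, read by MTT assay, with a stated time of 24 h, tested at 10 uM; a lower number here means less inhibition, a higher number more inhibition at the concentration tested (going by the name of the read-out). Compound 1 `CC(C)=CCOc1cc(=O)n(CCCO)c2c1CC(CC=C(C)C)C(C)(C)C2` gives 20.7%. Compound 2 `COc1ccccc1NC(=O)Oc1cc(=O)n(CCCO)c2c1CC(CC=C(C)C)C(C)(C)C2` gives 71.1%, and compound 3 `CC(C)=CCC1Cc2c(OC(=O)Nc3ccc(F)cc3)cc(=O)n(CCCO)c2CC1(C)C` gives 71.2%; this is the highest of the three numbers, yet compound 2 lies within the usual scatter of it, while the step of a number 50.5 percentage points higher from compound 1 to compound 3 (beyond the scatter) is large. Compound 4 `CC(C)=CCC1Cc2c(OC(=O)Nc3ccccc3F)cc(=O)n(CCCO)c2CC1(C)C` differs from compound 3 by 2-fluorophenyl in place of 4-fluorophenyl on an amide-type nitrogen. Among the compounds with values here, the one measured step that bears on this also exchanged the ring on the amide-type nitrogen: a number 0.1 percentage points higher from compound 2 to compound 3 (within the scatter). Since that exchange left this assay essentially unchanged, compound 4 is expected to show a number 3.2 percentage points lower from compound 3 to compound 4 (within the scatter), a move that stays within the scatter. Compound 4 is estimated at 68%, with a range from 54% to 80%.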

Compound 4, a percentage reported as inhibition, at one concentration (the size of the read-out at that concentration, not a potency): 52.3%
Beside the measured number, compound 4's estimate is 15.7 percentage points above it; measured number outside the range, below it.
By their numbers in this assay, from the lowest: compound 1; then compound 4; then compounds 2 and 3 (each within the scatter of the next).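

In this assay, the place of the fluorine on the ring counts: 2-fluorophenyl in place of 4-fluorophenyl gives a number 18.9 percentage points lower from compound 3 to compound 4 (beyond the scatter), although the earlier ring exchange stayed within the scatter. Fluoro in place of methoxy on the ring gives a number 18.8 percentage points lower from compound 2 to compound 4 (beyond the scatter), yet the (2-fluorophenyl)carbamoyl group still holds a large gain over 3-methylbut-2-en-1-yl, with a number 31.6 percentage points higher from compound 1 to compound 4 (beyond the scatter) on that oxygen. No measurement shown explains this difference. Still open, going by these compounds, is how a plain phenyl ring on the amide-type nitrogen would compare, and whether chloro or methyl in place of fluoro would behave alike.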